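Isopropyl ester in place of the nitrooxybutyl ester

The source may hold more compounds than are shown below. What is called first, only, known or untested is meant among the compounds shown, and "the series" means these compounds.

Of the compounds shown here, three of a shared core have been measured in a functional assay (ileum) for antagonist activity, with Cavia porcellus as the target; on this read-out higher numbers stand for weaker inhibition and lower numbers for stronger inhibition. Compound 1 `CC1=C(C(=O)O[C@H](C)CO[N+](=O)[O-])[C@H](c2cccc3nonc23)C([N+](=O)[O-])=C(C)C1` gives 36500 nM, compound 3 `CC1=C(C(=O)O[C@@H](C)CO[N+](=O)[O-])[C@@H](c2cccc3nonc23)C([N+](=O)[O-])=C(C)C1` gives 577 nM, and compound 2 `CC1=C(C(=O)OCCCCO[N+](=O)[O-])C(c2cccc3nonc23)C([N+](=O)[O-])=C(C)C1` gives 878 nM. Compound 2 thus stands second highest of the three numbers; its nearest neighbour is compound 3, within the scatter, and its furthest is compound 1, beyond it.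

Among the measured compounds shown here, the only measured step between single-change pairs is a 63-fold lower number from compound 1 to compound 3 (1.80 log units; beyond the scatter), a large shift that arises because the fact that compounds 1 and 3 differ only in the configuration as drawn the two compounds are mirror images of one another. That step concerns configuration alone and says nothing about the ester group.

Compound 4 `CC1=C(C(=O)OC(C)C)C(c2cccc3nonc23)C([N+](=O)[O-])=C(C)C1` is not yet measured. It differs from compound 2 as follows: isopropyl in place of 4-(nitrooxy)butyl on an oxygen next to a carbonyl group. For the measured compounds named here, no measured step touches this part of the molecule, so no step size can be read off for it; compound 2 itself, the most similar measured compound, serves as the anchor. On that basis compound 4 is expected to land near compound 2, with a 1.8-fold lower number from compound 2 to compound 4 (0.24 log units; within the scatter) as the estimated step, and a wide range around it. The estimated value for compound 4 in this assay is 500 nM, with a range from 80 nM to 3000 nM.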

Compound 4, half-maximal inhibitory concentration: 40 nM
Compound 4: middle estimate off by 13-fold (1.10 log units), on the high side; measured number below the stated range.
By their numbers in this assay, from the lowest: compound 4; then compounds 3 and 2 (each within the scatter of the next); then compound 1.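

In this assay, among the compounds shown here, the ester side chain on an oxygen next to a carbonyl group proves to be a position that moves the read-out, which the earlier compounds could not show because their only measured step concerned configuration: isopropyl in place of 4-(nitrooxy)butyl gives a 22-fold lower number from compound 2 to compound 4 (1.34 log units; beyond the scatter). The 4-(nitrooxy)butyl group is therefore not required for a low number in this assay, since the much smaller, all-carbon isopropyl group gives the lower number of this pair. Nothing at hand accounts for the size of this step.

For the compounds shown here, the single step changes chain length, branching and the presence of the nitrooxy group together, so it leaves open which of these matters; a plain butyl ester, a 2-(nitrooxy)ethyl ester or a methyl ester would each separate them differently. It also leaves open whether the mirror-image forms of compound 4 would differ as far as compound 1 and compound 3 do, and whether a carboxylic acid or an amide would be tolerated at this position.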